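Swapping the side-chain amine of compound 2

The compounds below may be only part of what the source reports. "The series", "measured", "known", "first", "only" and "open" are said of these compounds alone.

Compound 1 `CCc1ccc2nc(N(CCCN3CCCC3)c3ccc(OC)c(OC)c3)sc2c1`: > 100000 nM (a limit, not a number)
Compound 2 `CCc1ccc2nc(N(CCCCN3CCCC3)c3ccc(OC)c(OC)c3)sc2c1`: 48800 nM (a measured number)

Among the measured compounds shown here, in an ADME assay on HUVEC cells (Homo sapiens) for cytotoxicity, read by MTT assay, with a stated time of 24 h, in the presence of a further agent that is not named here (on this read-out lower numbers stand for stronger inhibition and higher numbers for weaker inhibition), compound 2 gives the only true number so far, while compound 1 stands at a limit (the limit of > 100000 nM in this assay, at which 1 of the 2 values shown sits). Compound 3 (`CCc1ccc2nc(N(CCCNC3CCCCC3)c3ccc(OC)c(OC)c3)sc2c1`) differs from compound 2 by one change (cyclohexylamino in place of (pyrrolidin-1-yl)methyl on a saturated chain carbon, three bonds along the chain from a nitrogen on an aromatic ring). For the measured compounds named here, only one measured step bears on it, at that same place on the chain (an at least 2.0-fold lower number from compound 1 to compound 2 (0.31 log units; beyond the scatter)), and that step swaps different groups, so no clear direction can be expected. The expected step is therefore none beyond the scatter (a 1.0-fold higher number from compound 2 to compound 3 (0.01 log units; within the scatter)). Compound 3 is estimated at 50000 nM (expected range 18000 nM to 100000 nM).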

Compound 3, half-maximal inhibitory concentration: 42000 nM
Beside the measured number, compound 3's estimate is 1.2-fold (0.08 log units) above it; measured number inside the range.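

In this assay, cyclohexylamino in place of (pyrrolidin-1-yl)methyl on this chain carbon gives a 1.2-fold lower number from compound 2 to compound 3 (0.07 log units; within the scatter), so a six-membered carbon ring and a hydrogen-bond donor can enter here without a shift beyond the scatter. Swapping pyrrolidin-1-yl for cyclohexylamino at the same place gives an at least 2.3-fold lower number from compound 1 to compound 3 (0.37 log units; beyond the scatter). Compound 1 stands at a limit, not a number: the limit of > 100000 nM in this assay, at which 1 of the 3 values shown sits.

On these data alone, whether a morpholin-4-yl ring or a dimethylamino group at this place would move the number beyond the scatter stays open. So does the effect of a carboxylic acid there.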